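Nitropyridyl in Place of Methylpyridyl on the Saturated Carbon

A few compounds are considered here, and "the series" means these few. Any claim that something is new, unique, unknown or untested is made for them only; others in the source may bear on it.

Measured so far:
compound 1 `CC1=NC(C)=C([N+](=O)[O-])C(c2cccc(C)n2)/C1=C(/O)OC(C)C`, a functional assay (muscle tissue) with Cavia porcellus as the target; on this read-out lower numbers stand for stronger inhibition and higher numbers for weaker inhibition: 25100 nM
compound 2 `CC1=NC(C)=C([N+](=O)[O-])C(c2cccc(C)n2)/C1=C(/O)OCCc1ccccc1`, this assay: 9980 nM

Compound 2 holds the lowest of the two numbers; compound 1 sits above it. Among the compounds with values here, the single measured step, a 2.5-fold lower number from compound 1 to compound 2 (0.40 log units; beyond the scatter), concerns only the ester side chain.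

Compound 3 `CC1=NC(C)=C([N+](=O)[O-])C(c2ncccc2[N+](=O)[O-])/C1=C(/O)OCCc1ccccc1` differs from compound 2 by 3-nitropyridin-2-yl in place of 6-methylpyridin-2-yl on a saturated ring carbon. Within the data shown here, no measured step touches the pyridyl group, so nothing points to a direction; the expected step is a 1.0-fold higher number from compound 2 to compound 3 (0.00 log units; within the scatter), i.e. no change beyond the scatter, with wide uncertainty. Compound 3 is therefore estimated at 10000 nM, with a range from 2500 nM to 40000 nM.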

Compound 3, half-maximal inhibitory concentration: 77700 nM
The estimate for compound 3 lay 7.8-fold (0.89 log units) below the measured number, and the stated range ends below it.
By their numbers in this assay, from the lowest: compound 2; then compound 1; then compound 3.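

The position on the saturated ring carbon is not neutral in this assay: 3-nitropyridin-2-yl in place of 6-methylpyridin-2-yl gives a 7.8-fold higher number from compound 2 to compound 3 (0.89 log units; beyond the scatter) with the phenethyl ester held constant. Within the data shown here, this is the first measured change to the pyridyl group, and its direction is towards weaker inhibition. No measurement on hand explains this step.

The swap removes the methyl and adds the nitro together, so their separate contributions stay unresolved. Unsubstituted pyridin-2-yl or 3-methylpyridin-2-yl at this position would separate them.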